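The compounds below may be only part of what the source reports. "The series", "measured", "known", "first", "only" and "open" are said of these compounds alone.

Compound 1 `Cc1ccccc1-c1cccc(-c2cc3nc(C)c([C@H](OC(C)(C)C)C(=O)O)c(-c4cc(F)c5c(c4C)CCCO5)n3n2)c1`: 95%
Compound 2 `Cc1nc2cc(-c3cccc(-c4ccccc4F)c3)nn2c(-c2cc(F)c3c(c2C)CCCO3)c1[C@H](OC(C)(C)C)C(=O)O`: 100%

In an ADME assay on microsomes from liver (Homo sapiens), read by LC-MS, using NADPH, with a stated time of 10 min, tested at 0.5 uM (a lower number here means that less of the compound is left, a higher number that more of the compound is left), compound 2 gives 100% and stands level with compound 1, given the scatter. Compound 3 `Cc1nc2cc(-c3cccc(-c4ccncc4)c3)nn2c(-c2cc(F)c3c(c2C)CCCO3)c1[C@H](OC(C)(C)C)C(=O)O` carries a new change, pyridin-4-yl in place of 2-fluorophenyl on an aromatic carbon: pyridin-4-yl in place of 2-fluorophenyl. Within the data shown here, only one measured step bears on it, and only loosely: a number 5 percentage points higher from compound 1 to compound 2 (within the scatter), with fluoro in place of methyl. Among the measured compounds shown here, no measured compound carries pyridin-4-yl, so a real drop cannot be ruled out, but no step beyond the scatter is expected. The expected change is a number 8 percentage points lower from compound 2 to compound 3 (within the scatter). For compound 3 the estimate is 92%, with an expected range from 72% to 100%.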

Compound 3, percent of the compound remaining: 46%
The estimate for compound 3 lay 46 percentage points above the measured number, outside the stated range (below it).
By their numbers in this assay, from the lowest: compound 3; then compounds 1 and 2 (each within the scatter of the next).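

This position is not indifferent to the ring it carries. In this assay, pyridin-4-yl in place of 2-fluorophenyl gives a number 54 percentage points lower from compound 2 to compound 3 (beyond the scatter), and in place of 2-methylphenyl it gives a number 49 percentage points lower from compound 1 to compound 3 (beyond the scatter), whereas fluoro and methyl on the phenyl ring had made no difference beyond the scatter. Nothing measured here explains this drop.

The compounds shown leave open whether the loss tracks the ring nitrogen or the missing fluoro or methyl group. Unsubstituted phenyl and 2-methylpyridin-4-yl would separate the two.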